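A few compounds are considered here, and "the series" means these few. Any claim that something is new, unique, unknown or untested is made for them only; others in the source may bear on it.

Working notes on the series, all in an ADME assay on microsomes from liver (Homo sapiens), read by LC-MS, with a stated time of 90 min; on this read-out lower numbers stand for lower hepatic extraction and higher numbers for higher hepatic extraction.

Compound 1, `CC[C@H](C)n1c(=O)[nH]c2ncc(Br)nc21`, gives < 0.2, which is a limit of this assay rather than a number. For compound 2, `CC(C)n1c(=O)[nH]c2ncc(Br)nc21`, the result in this assay is "not determined" (no result reported), so no number stands for it; what the series shows is the limit of < 0.2 in this assay, at which 1 of the 2 values shown sits. Compound 3, `CC(C)(C)n1c(=O)[nH]c2ncc(Br)nc21`, differs from compound 2 by methyl in place of hydrogen on a saturated chain carbon bound to an aromatic nitrogen and two saturated chain carbons. For the measured compounds named here, no measured step exists for this change, and the expected step in this assay is none beyond the usual scatter, with the result likely to sit again at the limit. Compound 3 is therefore estimated at 0.2, between 0.1 and 0.4.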

Compound 3, hepatic extraction ratio: 0.2
For compound 3 middle estimate and measured number coincide at the digits printed, within the range that was stated.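

In this assay, for the compounds shown here, compound 3 gives 0.2, the only reading that is a number and not a limit. With tert-butyl in place of sec-butyl on an aromatic nitrogen, the change reads as a number no lower from compound 1 to compound 3 (the limit leaves the size open), so its direction is bounded, but its size cannot be read. One limit still stands in the series: the limit of < 0.2 in this assay, at which 1 of the 3 values shown sits.

The compounds shown leave open how an amine, a carboxylic acid or a longer chain on this aromatic nitrogen would read in this assay. They also leave open whether any such group would give a value clearly apart from that of compound 3.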